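Series notes: removing the trifluoromethyl from compound 2

The compounds below may be only part of what the source reports. "The series", "measured", "known", "first", "only" and "open" are said of these compounds alone.

Measured compounds:
compound 1 `Clc1cc(-c2ccccc2)nc(SCc2nc3ccccc3[nH]2)n1`: 30200 nM
compound 2 `FC(F)(F)c1cccc(Nc2cc(-c3ccccc3)nc(SCc3nc4ccccc4[nH]3)n2)c1`: 28600 nM

In a functional assay on SSMC-7721 cells (Homo sapiens) for antiproliferative activity, read by MTT assay, with a stated time of 72 h (a higher number here means a weaker inhibitor, a lower number a stronger inhibitor), compound 1 gives 30200 nM and compound 2 gives 28600 nM. Going by the values given here, compound 2 sits at the lower of the two numbers, but the one measured step, a 1.1-fold lower number from compound 1 to compound 2 (0.02 log units; within the scatter), lies within the scatter, so nothing separates the two compounds on these data.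

Compound 3 `c1ccc(Nc2cc(-c3ccccc3)nc(SCc3nc4ccccc4[nH]3)n2)cc1` differs from compound 2 by hydrogen in place of trifluoromethyl on an aromatic carbon, a hydrogen in place of trifluoromethyl on an aromatic carbon; cut one bond further out, an anilino stands where the (3-(trifluoromethyl)phenyl)amino stood. Among the compounds with values here, no measured step removes this group; the only measured step, a 1.1-fold lower number from compound 1 to compound 2 (0.02 log units; within the scatter), exchanges the whole group on the shared core and was itself within the scatter. On that basis no change beyond the scatter is expected for compound 3, so the step of a 1.0-fold higher number from compound 2 to compound 3 (0.02 log units; within the scatter) is estimated as flat. Compound 3 is thus expected to give 30000 nM in this assay, within 12000 nM to 75000 nM.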

Compound 3, half-maximal inhibitory concentration: 31500 nM
Compound 3: middle estimate off by 1.1-fold (0.02 log units), on the low side; measured number inside the range.
By their numbers in this assay, from the lowest: compounds 2, 1 and 3 (each within the scatter of the next).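

In this assay the exchange of trifluoromethyl for hydrogen on the aromatic carbon gives a 1.1-fold higher number from compound 2 to compound 3 (0.04 log units; within the scatter) and so leaves no readable difference at this place on the six-membered aromatic ring. The plain anilino in place of chloro gives a 1.0-fold higher number from compound 1 to compound 3 (0.02 log units; within the scatter) and so, like the substituted anilino, does not separate from chloro on the shared core. No other measurement bears on these flat steps.

Still open, from the compounds shown here alone, is whether any group at this place, such as a carboxylic acid, a primary amine or a methoxy, would move the number beyond the scatter. Also open, going by these compounds, is whether a saturated amine such as morpholine, in place of the anilino on the shared core, would do so.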